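Changing the aryl group of compound 2

The source may hold more compounds than are shown below. What is called first, only, known or untested is meant among the compounds shown, and "the series" means these compounds.

In a functional assay on A549 cells (Homo sapiens) for cytotoxicity, read by MTT assay, with a stated time of 48 h (a higher number here means a weaker inhibitor, a lower number a stronger inhibitor), compound 1 `C#CC1=CC[C@@]2(C)C(=C)CCC[C@]2(C)CC1` gives 148000 nM and compound 2 `C=C1CCC[C@]2(C)CCC(c3cn(-c4ccc(OC)cc4)nn3)=CC[C@@]12C` gives 34700 nM, the lower of the two numbers, with the gap beyond the scatter. Compound 3 `C=C1CCC[C@]2(C)CCC(c3cn(-c4cccc([N+](=O)[O-])c4)nn3)=CC[C@@]12C` carries 3-nitrophenyl in place of 4-methoxyphenyl on an aromatic nitrogen. Among the compounds with values here, no measured pair isolates a change of this kind, so the expectation in this assay is no step beyond the scatter, with no firm direction. The estimated change is a 1.2-fold lower number from compound 2 to compound 3 (0.06 log units; within the scatter). For compound 3 the expected value is 30000 nM, with an estimated range of 11000 nM to 80000 nM.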

Compound 3, half-maximal inhibitory concentration: 24700 nM
Estimate against measurement, compound 3: 1.2-fold (0.08 log units) above, within the range that was stated.
By their numbers in this assay, from the lowest: compounds 3 and 2 (each within the scatter of the next); then compound 1.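

In this assay, within the data shown here, the only pair that isolates this position gives a 1.4-fold lower number from compound 2 to compound 3 (0.15 log units; within the scatter), so 3-nitrophenyl and 4-methoxyphenyl on an aromatic nitrogen cannot be told apart here. This exchange alters both the group on the phenyl ring and its place there, and neither alteration can be read alone. No measured property bears on this result.

Still open, on these data alone, is whether an amine or a carboxylic acid on the phenyl ring, or a longer alkyl chain in place of the aryl group, would give a step beyond the scatter. Also open, as far as these compounds go, is how the unsubstituted phenyl group compares with compound 2 and compound 3.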